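This account rests on a few compounds, and the source may have more. Where it says the series, first, only, none or still open, it means among the compounds named here.

Of the compounds shown here, three sharing a core have been measured so far in an ADME assay on the whole organism (Rattus norvegicus, strain Sprague-Dawley) for pharmacokinetics, using cassette dosing, at a dose of 1 mg/kg by the oral route; a lower number here means that a smaller share of the oral dose reaches the circulation, a higher number that a larger share of the oral dose reaches the circulation. Compound 1 (`O=C(c1cc(-c2cn[nH]c2)on1)N1CCC(Cc2ccccc2)CC1`) gives 0.2% and compound 2 (`O=C(c1cc(-c2cn[nH]c2)on1)N1CCC(Cc2ccc(Cl)cc2)CC1`) gives 0.6%, two values within the scatter of each other. Compound 3 (`O=C(c1cc(-c2ccc(=O)[nH]c2)on1)N1CCC(Cc2ccccc2)CC1`) gives 18.4% and stands highest of the three, beyond the scatter from both of the others.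

Compound 4 (`O=C(c1cc(-c2ccc(=O)[nH]c2)on1)N1CCC(Cc2ccc(F)cc2)CC1`) differs from compound 3 in one place (fluoro in place of hydrogen on an aromatic carbon), with fluoro in place of hydrogen on an aromatic carbon, turning benzyl into 4-fluorobenzyl. Two measured steps offer some guidance. The closest is a similar swap, chloro in place of hydrogen on an aromatic carbon (a number 0.4 percentage points higher from compound 1 to compound 2 (within the scatter)). It stayed within the scatter, although both of its values lie near zero, so it may say little about a compound at the level of compound 3. The other step replaced a different group, not the one changing here (a number 18.2 percentage points higher from compound 1 to compound 3 (beyond the scatter)), and it shows how much that other group can matter. No fluoro swap has been measured yet, so the expectation remains loose. The expected result is no change beyond the scatter (a number 0.4 percentage points lower from compound 3 to compound 4 (within the scatter)). For compound 4 the estimated value is 18% (expected range 7% to 32%).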

Compound 4, oral bioavailability: 18.4%
For compound 4 the middle estimate is 0.4 percentage points below the measured one; the range from low to high includes it.
By their numbers in this assay, from the lowest: compounds 1 and 2 (each within the scatter of the next); then compounds 3 and 4 (each within the scatter of the next).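

In this assay, putting fluoro in place of hydrogen on the six-membered aromatic ring of carbon only gives no change at the digits printed from compound 3 to compound 4 (within the scatter). The earlier chloro swap at this place, a number 0.4 percentage points higher from compound 1 to compound 2 (within the scatter), had both its values close to zero, where a loss would hardly have been visible, whereas compound 3 starts from 18.4% and leaves room for a fall, so this step gives the first sign that a halogen here can be tolerated once a real share of the oral dose reaches the circulation. Nothing available explains why the number holds at this level.

From the compounds shown here alone, it remains open whether other groups at this place, such as chloro on the compound 3 structure, a methoxy group, a nitrile or an amine, would leave the number just as undisturbed. For the compounds shown here, the one step beyond the scatter so far is the exchange of the other aromatic ring, a number 18.2 percentage points higher from compound 1 to compound 3 (beyond the scatter), and these compounds cannot say whether a further exchange there, for example to a ring bearing a carboxylic acid, would move the number again.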